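Chloro in place of hydroxy: expected effect on growth inhibition

A few compounds are considered here, and "the series" means these few. Any claim that something is new, unique, unknown or untested is made for them only; others in the source may bear on it.

Compound 1 `COc1ccc(C(=O)/C=C/c2cc3ccccc3[nH]c2=O)cc1`: in a functional assay on HL-60 cells (Homo sapiens) for cytotoxicity, read by sulforhodamine B assay, with a stated time of 24 h (on this read-out lower numbers stand for stronger inhibition of growth and higher numbers for weaker inhibition of growth), compound 1 gives only a limit, > 100000 nM.
Compound 2 `O=C(/C=C/c1cc2ccccc2[nH]c1=O)c1ccc(O)cc1`: in this assay compound 2 gives 6860 nM.

Within the data shown here, compound 2 holds the only actual number in this assay; the other value shown is a limit. Among the measured compounds shown here, the single measured step, an at least 14-fold lower number from compound 1 to compound 2 (1.16 log units; beyond the scatter), rests on the limit of > 100000 nM in this assay, at which 1 of the 2 values shown sits, and so gives only a floor for its size. Compound 3 `O=C(/C=C/c1cc2ccccc2[nH]c1=O)c1ccc(Cl)cc1` differs from compound 2 by chloro in place of hydroxy on an aromatic carbon. For the measured compounds named here, no measured step covers this exchange directly. Because an at least 14-fold lower number from compound 1 to compound 2 (1.16 log units; beyond the scatter) went with hydrogen in place of methyl on that oxygen, the loss of the hydroxy in compound 3 is expected to weaken growth inhibition, though its extent is uncertain. Compound 3 is therefore estimated to give 20000 nM in this assay, within 5000 nM to 100000 nM, an expected step of a 2.9-fold higher number from compound 2 to compound 3 (0.46 log units; beyond the scatter).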

Compound 3, concentration for total growth inhibition: > 100000 nM
Compound 3: no number, only a limit; the forecaster's own chance of this, stated with the estimate: 30%; middle value at least 5.0-fold (0.69 log units) from the limit.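

In this assay compound 3 gives only a limit, > 100000 nM. Chloro in place of hydroxy at this position, para to a large group, gives an at least 14-fold higher number from compound 2 to compound 3 (1.16 log units; beyond the scatter), so a second replacement of the hydroxy, and not only its methyl ether, goes with weaker growth inhibition. Of the three compounds shown, only compound 2, the one with the free hydroxy, gives an actual number.

The step between compound 1 and compound 3 cannot be read, and methoxy and chloro cannot be ranked against each other: the limit of > 100000 nM in this assay, at which 2 of the 3 values shown sit.

On these data alone, whether an amine or a carboxylic acid at this position would keep growth inhibition, or whether only the hydroxy does so, stays open.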